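Moving the methylpyrazole attachment point in compound 3

The compounds below may be only part of what the source reports. "The series", "measured", "known", "first", "only" and "open" are said of these compounds alone.

Compound 2 `CNC(=O)N1CCCc2ccc(NC(=O)c3ccc(-c4ccn(C)n4)cc3)cc21` stands lowest of the two compounds measured in a functional assay on MV4-11 cells (Homo sapiens) for antiproliferative activity, with a stated time of 6 days, tested at 1.56 uM (a higher number here means a stronger effect of the compound at the concentration tested, a lower number a weaker effect), where compound 2 gives 72.2% while compound 1 `CNC(=O)N1CCCc2ccc(NC(=O)c3ccc(-c4cc[nH]n4)cc3)cc21` gives 92.5%. For the measured compounds named here, the step of a number 20.3 percentage points lower from compound 1 to compound 2 (beyond the scatter) concerns methyl in place of hydrogen on an aromatic nitrogen, a change unlike the one leading to compound 3 `CNC(=O)N1CCCc2ccc(NC(=O)c3ccc(-c4cnn(C)c4)cc3)cc21`, in which (1-methyl-1H-pyrazol-4-yl in place of 1-methyl-1H-pyrazol-3-yl on an aromatic carbon). No measured step matches this rearrangement, so neither direction nor size can be read from the two numbers shown. Compound 3 is therefore estimated near 60%, within 30% to 90%. The expected step of a number 12.2 percentage points lower from compound 2 to compound 3 (beyond the scatter) is an estimate only, and a result within the scatter is expected.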

Compound 3, a percentage reported as inhibition, at one concentration (the size of the read-out at that concentration, not a potency): 77.4%
Compound 3: middle estimate off by 17.4 percentage points, on the low side; measured number inside the range.
By their numbers in this assay, from the lowest: compounds 2 and 3 (each within the scatter of the next); then compound 1.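

In this assay moving the attachment point of the methylpyrazole gives a number 5.2 percentage points higher from compound 2 to compound 3 (within the scatter) and so does not separate 1-methyl-1H-pyrazol-4-yl from 1-methyl-1H-pyrazol-3-yl at this place, on an aromatic carbon para to a large group. The second comparison, a number 15.1 percentage points lower from compound 1 to compound 3 (beyond the scatter), shows that 1H-pyrazol-3-yl also stays ahead of the methylated isomer with the other attachment point. No evidence is available to explain either step. The compounds shown leave open how 1H-pyrazol-4-yl would compare with compound 1, and how an ethyl group or a longer chain on the pyrazole nitrogen would behave.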